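Phenoxy in place of 2-chlorophenyl on the benzyl ether arm

This account rests on a few compounds, and the source may have more. Where it says the series, first, only, none or still open, it means among the compounds named here.

Compound 1, `Cc1cccc(C)c1-c1cccc(COc2ccc(SCC(=O)O)cc2)c1`, gives 195 nM in a functional assay on CHO cells for agonist activity at Free fatty acid receptor 1 (Homo sapiens), read by FLIPR and calcium flux; a higher number here means that more compound is needed for the effect, a lower number that less compound is needed.
Compound 2, `Cc1cc(OCCCS(C)(=O)=O)cc(C)c1-c1cccc(COc2ccc(S(=O)(=O)CC(=O)O)cc2)c1`, gives 170 nM in this assay.
Compound 3, `O=C(O)CS(=O)(=O)c1ccc(OCc2cccc(-c3ccccc3Cl)c2)cc1`, gives 28.8 nM in this assay.

Of the three numbers, compound 3 stands lowest, and its gaps to compound 2 and to compound 1 both lie beyond the usual scatter. For the measured compounds named here, no pair of measured compounds differs in a single place, so no measured step guides the next change. Compound 4, `O=C(O)CS(=O)(=O)c1ccc(OCc2cccc(Oc3ccccc3)c2)cc1`, is compound 3 with phenoxy in place of 2-chlorophenyl on an aromatic carbon. Going by the values given here, with no comparable step in hand, a moderate loss is expected rather than a gain, and the step of a 2.4-fold higher number from compound 3 to compound 4 (0.39 log units; beyond the scatter) is estimated with wide uncertainty. Compound 4 is expected to give 70 nM in this assay, in a range from 22 nM to 220 nM.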

Compound 4, half-maximal effective concentration: 97.7 nM
The estimate for compound 4 lay 1.4-fold (0.14 log units) below the measured number; low and high end bracket the measured number.
By their numbers in this assay, from the lowest: compound 3; then compounds 4, 2 and 1 (each within the scatter of the next).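

Phenoxy in place of 2-chlorophenyl gives the first single-place step in the series: in this assay, a 3.4-fold higher number from compound 3 to compound 4 (0.53 log units; beyond the scatter). This position on the aromatic carbon therefore responds to the exchange, even though both groups carry one six-membered aromatic ring of carbon only. No available evidence accounts for the size of this step.

From the compounds shown here alone, it remains open whether the higher number follows from losing the chlorine or from adding the ether oxygen. An unsubstituted phenyl or a 2-chlorophenoxy group at this position would separate the two.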